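This account rests on a few compounds, and the source may have more. Where it says the series, first, only, none or still open, it means among the compounds named here.

Of the compounds shown here, three that share one core have been measured in a physicochemical assay for lipophilicity, read by LC-MS, in phosphate buffer, measured as octanol-water partition, with a stated time of 30 min, at pH 7.4, tested at 200 mM; on this read-out higher numbers stand for higher lipophilicity and lower numbers for lower lipophilicity. Compound 1 `Cn1c(COc2cccc(C(=O)O)c2)nc2ccc(Oc3ccc(F)cc3)nc21` gives 1.5, compound 2 `Cn1c(COc2cccc(C(=O)O)c2)nc2cnc(Oc3ccc4c(c3)OCC4)cc21` gives 0.6, and compound 3 `Cn1c(COc2cccc(C(=O)O)c2)nc2ccc(Oc3ccc(Cl)cn3)cc21` gives 1.2. On these numbers compound 3 stands second highest of the three: its value and that of compound 1 lie within the usual scatter of each other, while compound 2 sits clearly lower, beyond the scatter. Compound 4 `Cc1ccc(Oc2ccc3nc(COc4cccc(C(=O)O)c4)n(C)c3c2)nc1C` has not yet been measured in this assay. It differs from compound 3 in one place: 5,6-dimethylpyridin-2-yl in place of 5-chloropyridin-2-yl on an oxygen on an aromatic ring. Among the measured compounds shown here, no measured pair shows this change, so the step can only be estimated; a modest rise in this assay is expected, a number 0.40 log units higher from compound 3 to compound 4 (beyond the scatter). Compound 4 is expected to give about 1.6, within a range from 1.1 to 2.1.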

Compound 4, distribution coefficient: 1.3
Compound 4: the middle estimate sits 0.30 log units above what was measured, within the range that was stated.
By their numbers in this assay, from the lowest: compound 2; then compounds 3, 4 and 1 (each within the scatter of the next).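

Among the compounds shown here, on an oxygen on an aromatic ring, 5,6-dimethylpyridin-2-yl in place of 5-chloropyridin-2-yl gives a number 0.10 log units higher from compound 3 to compound 4 (within the scatter) in this assay, the first step here between two measured compounds that differ in one place. On this core, the exchange therefore leaves the read-out unchanged beyond the usual scatter. No measurement at hand gives a reason for this outcome.

On these data alone, whether an amine or a methoxy group on the pyridine ring would read the same remains open. So does whether this step would hold on a different core.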